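The source may report more compounds than this note shows. Statements on the series, on what has been measured and on what is new or still open speak of the compounds shown alone.

Compound 1 `COc1ccc(/C=C2/N=C(c3ccccc3)N(c3ccc4oc(-c5ccccc5)cc(=O)c4c3)C2=O)cc1` was tested in a functional assay on MDA-MB-435 cells (Homo sapiens) for inhibition, read by MTT assay (a lower number here means a stronger inhibitor, a higher number a weaker inhibitor), and in this assay compound 1 gives 18.5 ug/mL. Alongside it stands compound 2 `COc1ccc(/C=C2/N=C(c3ccccc3)N(c3ccc4oc(-c5ccccc5)cc(=O)c4c3)C2=O)cc1OC`, which in this assay gives 10.8 ug/mL. Going by the values given here, of these two numbers, that of compound 1 is the higher, and the only measured step, a 1.7-fold lower number from compound 1 to compound 2 (0.23 log units; within the scatter), lies within the scatter of repeated measurements, so the two compounds cannot be told apart on potency.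

Compound 3 `O=C1/C(=C\c2ccc(O)cc2)N=C(c2ccccc2)N1c1ccc2oc(-c3ccccc3)cc(=O)c2c1` is the one not yet measured. It differs from compound 1 in one place: hydrogen in place of methyl on an oxygen on an aromatic ring. Among the compounds with values here, no measured step changes a methoxy group into a hydroxy group, so the only guide is the single step recorded, which shows that adding a methoxy group to compound 1 moved the number within the scatter; the change to compound 3 removes a methyl from an existing methoxy group instead, and nothing in the data shows such a change shifting the number beyond the scatter. The step of a 1.0-fold lower number from compound 1 to compound 3 (0.01 log units; within the scatter) is therefore expected to stay within the scatter. For compound 3 the estimate is 18 ug/mL, with a range from 8 ug/mL to 40 ug/mL.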

Compound 3, half-maximal inhibitory concentration: 18 ug/mL
Estimate against measurement, compound 3: no gap at the digits printed, and the stated range covers the measured number.
By their numbers in this assay, from the lowest: compounds 2, 3 and 1 (each within the scatter of the next).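

In this assay the change from 4-methoxyphenyl to 4-hydroxyphenyl gives a 1.0-fold lower number from compound 1 to compound 3 (0.01 log units; within the scatter) and so shows that the methyl on this oxygen can give way to hydrogen with no difference the assay can detect. The larger change from 3,4-dimethoxyphenyl to 4-hydroxyphenyl gives a 1.7-fold higher number from compound 2 to compound 3 (0.22 log units; within the scatter) and also stays within the scatter, although it alters the ring in more than one way. The earlier pair compared only two methoxy patterns, whereas these steps add a free hydroxy group and show that none of the three substituted phenyl groups can be told apart from the others on potency.

The compounds shown leave open whether a different group on this ring, such as an amine, a carboxylic acid or a longer chain on the oxygen, would move the number beyond the scatter. They also leave open whether any change at this place matters at all, since every step seen so far lies within the scatter. No outside measurement is available to explain this flat result.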